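Estimating Solubility of a Benzyl-Bearing Pyrrolidine Analogue

This account rests on a few compounds, and the source may have more. Where it says the series, first, only, none or still open, it means among the compounds named here.

Compound 1 `O=C(CN1CCCC1)N1CCC(NS(=O)(=O)c2cc(S(=O)(=O)c3ccccc3)ccc2C(F)(F)F)CC1`: 25000 nM
Compound 2 `CC(C)(C)C(=O)N1CCC[C@H]1C(=O)N1CCC(NS(=O)(=O)c2cc(S(=O)(=O)c3ccccc3)ccc2C(F)(F)F)CC1`: 50000 nM
Compound 3 `CC(C)(C)CC(=O)N1CCC[C@H]1C(=O)N1CCC(NS(=O)(=O)c2cc(S(=O)(=O)c3ccccc3)ccc2C(F)(F)F)CC1`: 25000 nM

In a physicochemical assay for solubility (a lower number here means a less soluble compound, a higher number a more soluble compound), compound 1 stands level with compound 3 and shows a 2.0-fold higher number from compound 1 to compound 2 (0.30 log units; within the scatter); all three numbers sit within the scatter of each other. Compound 4 `O=C([C@@H]1CCCN1Cc1ccccc1)N1CCC(NS(=O)(=O)c2cc(S(=O)(=O)c3ccccc3)ccc2C(F)(F)F)CC1` has not yet been measured. It differs from compound 1 by 1-benzylpyrrolidin-2-yl in place of (pyrrolidin-1-yl)methyl on a carbonyl carbon. Among the measured compounds shown here, the steps that bear on this are a 2.0-fold higher number from compound 1 to compound 2 (0.30 log units; within the scatter) and no change at the digits printed from compound 1 to compound 3 (within the scatter), each also swapping the (pyrrolidin-1-yl)methyl for a substituted pyrrolidin-2-yl, and neither moved beyond the scatter. For the measured compounds named here, no measured step introduces a benzyl group, so the expectation rests on those two. For compound 4 the step expected is a 1.7-fold lower number from compound 1 to compound 4 (0.22 log units; within the scatter), meaning little change, with a slight lean downward. Compound 4 is thus estimated at 15000 nM, within 5000 nM to 40000 nM.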

Compound 4, solubility: 25000 nM
The estimate for compound 4 lay 1.7-fold (0.22 log units) below the measured number; the measured number falls inside the stated range.
By their numbers in this assay, from the lowest: compounds 1, 3, 4 and 2 (each within the scatter of the next).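

Replacing (pyrrolidin-1-yl)methyl with 1-benzylpyrrolidin-2-yl on the carbonyl carbon adds a six-membered aromatic ring of carbon only, yet it gives no change at the digits printed from compound 1 to compound 4 (within the scatter) in this assay. On the amine nitrogen in a ring, benzyl in place of neopentylcarbonyl gives no change at the digits printed from compound 3 to compound 4 (within the scatter), while benzyl in place of (tert-butyl)carbonyl gives a 2.0-fold lower number from compound 2 to compound 4 (0.30 log units; within the scatter), so all these swaps stay within the scatter. Nothing measured here explains this flat picture.

As far as these compounds go, whether an amine or carboxylic acid on the benzyl ring would shift the number beyond the scatter remains open.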